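A Second Nitrile Chain at the Assay Limit

The source may hold more compounds than are shown below. What is called first, only, known or untested is meant among the compounds shown, and "the series" means these compounds.

Compound 1 `CCn1c(C(=O)N(C)CCC#N)ccc1C(CC)(CC)c1ccc(OCC(O)C(C)(C)C)c(C)c1` and compound 2 `C=CCN(C)C(=O)c1ccc(C(CC)(CC)c2ccc(OCC(O)C(C)(C)C)c(C)c2)n1CC` share one core and differ in a single place. In a functional assay on HepG2 cells (Homo sapiens), read by MTT assay, with a stated time of 48 h (a higher number here means a weaker inhibitor, a lower number a stronger inhibitor), compound 1 gives > 50000 nM, which is a limit of the assay and not a number. In this assay compound 2 gives > 50000 nM, which is also a limit, so compound 2 has no exact value.

Compound 3 `CCn1c(C(=O)N(CCC#N)CCC#N)ccc1C(CC)(CC)c1ccc(OCC(O)C(C)(C)C)c(C)c1` alters compound 2 on a carbonyl carbon, where the allyl(methyl)amino group leaves: a group of 9 heavy atoms (6 carbon, 3 nitrogen; no ring) in place of a group of 5 heavy atoms (4 carbon, 1 nitrogen; no ring), on a carbonyl carbon.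

Within the data shown here, the one measured step that bears on this is a step that the two limits leave unreadable from compound 1 to compound 2. It also changes a chain on an amide-type nitrogen, but its size cannot be read. No readable step is therefore expected in this assay, in either direction, because the limit of > 50000 nM in this assay, at which 2 of the 2 values shown sit, gives no measured size to build on. The step expected is a number no higher from compound 2 to compound 3 (the limit leaves the size open), and this is only a rough estimate. The estimate for compound 3 is 50000 nM, with an expected range of 20000 nM to 100000 nM, and a further limit is the likeliest report.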

Compound 3, half-maximal inhibitory concentration: 42000 nM
Compound 3: middle estimate off by 1.2-fold (0.08 log units), on the high side; low and high end bracket the measured number.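

In this assay compound 3 gives 42000 nM, the only exact number among the compounds shown. Compound 2, which differs from compound 3 on a carbonyl carbon, gives only a limit. Swapping the allyl(methyl)amino group for the group with two nitrile chains gives an at least 1.1-fold lower number from compound 2 to compound 3 (0.07 log units; that floor lies within the scatter), while adding cyanomethyl in place of hydrogen on the chain of compound 1 gives an at least 1.1-fold lower number from compound 1 to compound 3 (0.07 log units; that floor lies within the scatter), and neither step can be called a real gain on these figures. Going by these compounds, both are only floors, and their true size stays unknown, because the other two compounds give limits and not numbers: the limit of > 50000 nM in this assay, at which 2 of the 3 values shown sit.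

Among these compounds, with a single exact value, there is still no measured step against which the size of any other change could be judged. On these data alone, whether a longer chain ending in a nitrile, a carboxylic acid or an amine on the amide nitrogen would give a clearly lower number than compound 3 remains open, as does the effect of any change elsewhere on the shared core.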